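This account rests on a few compounds, and the source may have more. Where it says the series, first, only, none or still open, it means among the compounds named here.

Measured compounds:
compound 1 `CC(=O)OCc1cccc2c1CCOC2=O` — > 2430000 nM
compound 2 `CCOCC(=O)OCc1cccc2c1CCOC2=O` — > 3680000 nM

In an ADME assay on HepG2 2.2.15 cells (Homo sapiens) for cytotoxicity, read by MTT assay, with a stated time of 72 h (on this read-out lower numbers stand for higher toxicity in this test and higher numbers for lower toxicity in this test), compound 1 gives > 2430000 nM, which is a limit of the assay and not a number. In this assay compound 2 gives > 3680000 nM, again a limit. Compound 2 thus stands at the limit of > 3680000 nM in this assay, at which 1 of the 2 values shown sits, and with compound 1 sitting at the limit of > 2430000 nM in this assay, at which 1 of the 2 values shown sits, the step that the two limits leave unreadable from compound 1 to compound 2 cannot be read in either direction. Compound 3 `O=C(OCc1cccc2c1CCOC2=O)c1ccco1` differs from compound 2 by furan-2-yl in place of ethoxymethyl on a carbonyl carbon. Going by the values given here, the only measured step, a step that the two limits leave unreadable from compound 1 to compound 2, touches a different part of the ester and gives no readable size, so it offers no guidance on the new change. Since both measured compounds sit at limits, compound 3 is expected to do the same, with a step of an at least 1.4-fold lower number from compound 2 to compound 3 (0.16 log units; that floor lies within the scatter) that means no change beyond the scatter. Compound 3 is estimated at 2500000 nM, between 500000 nM and 6000000 nM, most likely reported as a limit.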

Compound 3, half-maximal cytotoxic concentration: > 2350000 nM
Compound 3 gave a limit, no number; the forecaster's own chance of this, stated with the estimate: 80%; the middle value does not contradict the limit.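

In this assay compound 3 gives > 2350000 nM, a limit of the assay and not a number. The steps linking compound 1, compound 2 and compound 3 cannot be read. The compounds shown leave open whether methyl, ethoxymethyl or furan-2-yl on the carbonyl carbon changes the read-out at all.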